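Dropping one chloro from compound 1: what to expect

A few compounds are considered here, and "the series" means these few. Any claim that something is new, unique, unknown or untested is made for them only; others in the source may bear on it.

Measured so far in a functional assay on CAKI-1 cells (Homo sapiens) for cytotoxicity, read by sulforhodamine B assay, with a stated time of 48 h; a higher number here means that more compound is tolerated, a lower number that less compound is tolerated:
- compound 1 `ClCc1ccc(Cn2cnc3nc(Cl)nc(Cl)c32)cc1`: 5370 nM
- compound 2 `ClCc1cccc(Cn2cnc3c(Cl)nc(Cl)nc32)c1`: 22900 nM
- compound 3 `ClCc1ccccc1Cn1cnc2ncnc(Cl)c21`: 7410 nM

Compound 1 gives the lowest of these three numbers, meaning the least compound is tolerated by the cells. Compound 3 sits close enough that the gap between the two lies within the usual scatter of repeated measurements, so no order between them can be claimed. Compound 2, by contrast, tolerates clearly more compound, a gap that lies beyond the scatter.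

Compound 4 `ClCc1ccc(Cn2cnc3ncnc(Cl)c32)cc1` is not yet measured. It differs from compound 1 in one place: hydrogen in place of chloro on an aromatic carbon — that is, a hydrogen in place of chloro on an aromatic carbon.

For the measured compounds named here, no measured pair shows exactly this change. The comparison between compound 1 and compound 3, which also carries only one chloro on the shared core, shows no gap beyond the scatter, so for compound 4 a step of a 1.3-fold higher number from compound 1 to compound 4 (0.12 log units; within the scatter) is expected, with no shift beyond the scatter. The estimate for compound 4 in this assay is 7000 nM, with a range from 2500 nM to 20000 nM.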

Compound 4, concentration lethal to 50% of the cells: 9770 nM
Compound 4: the middle estimate sits 1.4-fold (0.14 log units) below what was measured; the measured number falls inside the stated range.
By their numbers in this assay, from the lowest: compounds 1, 3 and 4 (each within the scatter of the next); then compound 2.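

In this assay, for the compounds shown here, putting hydrogen in place of the chloro that sits between two ring nitrogen atoms gives a 1.8-fold higher number from compound 1 to compound 4 (0.26 log units; within the scatter) and is the first direct reading of this change. Removing this chloro from the shared core, while the other chloro stays, therefore produces no shift that can be told apart from repeat-to-repeat variation. Nothing measured here offers an explanation for this result.

Still open, going by these compounds, is whether a larger group at this position, such as an amine or a methoxy group, would move the number beyond the scatter.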